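Adding Benzoyl to the Thiourea Nitrogen of Compound 3

The source may report more compounds than this note shows. Statements on the series, on what has been measured and on what is new or still open speak of the compounds shown alone.

Compound 1 `NC(=S)N1CCCc2c(OCCCCCOc3cccc4ccccc34)cccc21` sits at a limit of the assay in an ADME assay on Huh-7 cells (Homo sapiens) for cytotoxicity (on this read-out lower numbers stand for higher toxicity in this test and higher numbers for lower toxicity in this test), reported as > 50000 nM. Compound 2 `NC(=S)N1CCc2c(OCCCCCOc3ccc(Cl)cc3)cccc21` likewise sits at a limit, reported as > 50000 nM. Compound 3 `NC(=S)n1ccc2c(OCCCCCOc3ccc(Cl)cc3)cccc21` gives 24700 nM.

Within the data shown here, compound 3 is thus the only compound with an actual number in this assay; the other two values are limits, as seen in the limit of > 50000 nM in this assay, at which 2 of the 3 values shown sit. Compound 4 `O=C(NC(=S)n1ccc2c(OCCCCCOc3ccc(Cl)cc3)cccc21)c1ccccc1` differs from compound 3 by benzoyl in place of hydrogen on an amide-type nitrogen. Among the measured compounds shown here, no measured pair of compounds shows this change, so only a step of about the usual scatter is expected, with no clear direction. Compound 4 is estimated at 30000 nM, within a range from 9000 nM to 60000 nM. This means an expected step of a 1.2-fold higher number from compound 3 to compound 4 (0.08 log units; within the scatter).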

Compound 4, half-maximal cytotoxic concentration: 29500 nM
For compound 4 the middle estimate is 1.0-fold (0.01 log units) above the measured one, within the range that was stated.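

In this assay, benzoyl in place of hydrogen on this amide-type nitrogen gives a 1.2-fold higher number from compound 3 to compound 4 (0.08 log units; within the scatter). This nitrogen therefore takes on a whole benzoyl group, aromatic ring included, with no change in the read-out beyond the scatter. Compound 3 and compound 4 both give actual numbers, so this step can be read, which values at the limit would not allow: the limit of > 50000 nM in this assay, at which 2 of the 4 values shown sit.

Going by these compounds, whether acetyl, or a benzoyl carrying an amine or a carboxylic acid, would move the read-out at this nitrogen stays open. So does the effect of benzoyl on the core of compound 1 or compound 2.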